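Fluorostilbenes as activators in the reporter assay

A few compounds are considered here, and "the series" means these few. Any claim that something is new, unique, unknown or untested is made for them only; others in the source may bear on it.

Measured so far:
- compound 1, `Fc1ccccc1/C=C/c1ccccc1`: 700 nM
- compound 2, `Fc1cccc(/C=C/c2ccccc2F)c1`: > 15000 nM
- compound 3, `Fc1ccc(/C=C/c2cccc(F)c2)cc1`: 650 nM

In an assay on HepG2 cells for activation of nuclear factor erythroid 2-related factor 2 (Homo sapiens), read by a luciferase reporter, with a stated time of 5 h (a lower number here means that less compound is needed, a higher number that more compound is needed for the effect), compound 1 gives 700 nM. For compound 2 the assay reports only a limit, > 15000 nM, and no number. Compound 3 gives 650 nM in this assay; against compound 1 this is within the usual scatter, so no order between the two can be read.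

Going by the values given here, the one measured step with a single change is an at least 21-fold higher number from compound 1 to compound 2 (1.33 log units; beyond the scatter). The change is fluoro in place of hydrogen on an aromatic carbon. Its size is bounded only from below because of the limit of > 15000 nM in this assay, at which 1 of the 3 values shown sits.

The difference between the core of compound 1 and the core of compound 3 is not broken down here.

Compound 4, `Fc1ccc(/C=C/c2ccc(F)c(F)c2)cc1`, is not yet measured in this assay. It differs from compound 3 by fluoro in place of hydrogen on an aromatic carbon. This is the same kind of change as from compound 1 to compound 2, not the same: the earlier fluoro entered "meta to a group of 9 heavy atoms", the new one enters "ortho to a fluoro group (1 heavy atom); para to a group of 9 heavy atoms".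

With a single precedent at a different place, the expectation rests on the size of an at least 21-fold higher number from compound 1 to compound 2 (1.33 log units; beyond the scatter) tempered by the difference in place; a loss smaller than that is expected, a 3.8-fold higher number from compound 3 to compound 4 (0.59 log units; beyond the scatter). Compound 4 is expected to give about 2500 nM, estimated between 600 nM and 12000 nM.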

Compound 4, half-maximal effective concentration: > 15000 nM
Compound 4: no number, only a limit; the forecaster's own chance of this, stated with the estimate: 20%; middle value at least 6.0-fold (0.77 log units) away from the limit.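

Compound 4 gives no number in this assay, only a limit, > 15000 nM. Fluoro in place of hydrogen on an aromatic carbon brings an at least 23-fold higher number from compound 3 to compound 4 (1.36 log units; beyond the scatter), so on both cores shown this change goes with a loss beyond the scatter, here with the fluoro ortho to a fluoro group and para to a group of 9 heavy atoms. This is a shared direction across two cores and two places, not a transferable size, and two examples do not show that the loss would carry over to further cores in the series: the same change on two cores in this assay, an at least 21-fold higher number (1.33 log units; beyond the scatter) from compound 1 to compound 2 and an at least 23-fold higher number (1.36 log units; beyond the scatter) from compound 3 to compound 4; the limit leaves it open whether they differ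

Compound 2 and compound 4 cannot be ranked against each other, and how much activity each retains stays unknown: the limit of > 15000 nM in this assay, at which 2 of the 4 values shown sit. Fluoro is the only entering group among the compounds shown, so it remains open whether a hydroxyl, a methoxy, an amine or a carboxylic acid at the same places would keep a measurable number in this assay.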